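The source may hold more compounds than are shown below. What is called first, only, known or untested is meant among the compounds shown, and "the series" means these compounds.

Compound 1 `Cc1cc(C(=O)O)ccc1OCCCCOc1ccc(C(=O)CC(C)C)c(O)c1C` gives 192 nM in an assay on HEK293 cells for positive allosteric modulation of metabotropic glutamate receptor 2 (Rattus norvegicus), read by thallium flux, with a stated time of 2.5 min; a lower number here means that less compound is needed, a higher number that more compound is needed for the effect.
Compound 2 `COc1cc(C(=O)O)ccc1OCCCCOc1ccc(C(=O)CC(C)C)c(O)c1C` gives 40 nM in this assay.
Compound 3 `Cc1c(OCCCCOc2ccc(C(=O)O)cc2F)ccc(C(=O)CC(C)C)c1O` gives 102 nM in this assay.

Of these three numbers, compound 1 has the highest. The nearest is compound 3, reached by a 1.9-fold lower number from compound 1 to compound 3 (0.27 log units; within the scatter), a step that stays within the usual scatter of repeated measurements. The furthest is compound 2, reached by a 4.8-fold lower number from compound 1 to compound 2 (0.68 log units; beyond the scatter). Between compound 2 and compound 3 the step is a 2.6-fold higher number from compound 2 to compound 3 (0.41 log units; beyond the scatter).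

Compound 4 `CCCC(=O)c1ccc(OCCCCOc2ccc(C(=O)O)cc2C)c(C)c1O` has not yet been measured in this assay. It differs from compound 1 in a single place: hydrogen in place of methyl on a saturated chain carbon bound to two saturated chain carbons. Seen one bond further out, the isobutylcarbonyl of compound 1 becomes a propylcarbonyl in compound 4. All three measured steps swap a group sitting on an aromatic carbon; none of them touches a saturated chain carbon, so no measured step bears directly on this change, and the size and direction of its effect have no guide in the data shown. In the absence of such a guide, the step from compound 1 to compound 4 in this assay is expected to be a 1.5-fold higher number from compound 1 to compound 4 (0.16 log units; within the scatter), with a deliberately wide range. Compound 4 is therefore estimated at 280 nM, between 90 nM and 900 nM.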

Compound 4, half-maximal effective concentration: 104 nM
Compound 4: middle estimate off by 2.7-fold (0.43 log units), on the high side; the measured number falls inside the stated range.
By their numbers in this assay, from the lowest: compound 2; then compounds 3, 4 and 1 (each within the scatter of the next).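

Replacing the isobutylcarbonyl with a propylcarbonyl gives a 1.8-fold lower number from compound 1 to compound 4 (0.27 log units; within the scatter) in this assay. Among the compounds shown here, the earlier steps all swapped groups on aromatic carbons, so this is the first measured change on a saturated chain carbon, and it shows that the methyl on this carbon can be replaced by hydrogen without a difference that stands clear of the usual scatter between repeated measurements. No supporting measurement is available to explain why the two compounds read so closely.

From the compounds shown here alone, this single swap removes one methyl and says little about how much room for change this end of the molecule allows, so it remains open whether a longer chain such as a pentylcarbonyl, a ring such as a cyclopropylcarbonyl, or an amine on this chain would also stay within the scatter of compound 1. The compounds shown also leave open whether the same swap from isobutylcarbonyl to propylcarbonyl would give a similarly small step on compound 2, which carries a methoxy in place of the methyl on an aromatic carbon.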